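Trifluorophenyl for Trimethoxyphenyl on a Cinnamamide Benzophenone

A few compounds are considered here, and "the series" means these few. Any claim that something is new, unique, unknown or untested is made for them only; others in the source may bear on it.

Measured so far:
compound 1, `COc1ccc(C(=O)c2cc(OC)c(OC)c(OC)c2)cc1NC(=O)/C=C/c1ccc(F)cc1`, 60 nM
compound 2, `COc1cc(C(=O)c2cc(OC)c(OC)c(OC)c2)cc(NC(=O)/C=C/c2cc(OC)c(OC)c(OC)c2)c1OC`, 2500 nM

In a functional assay on HeLa cells (Homo sapiens) for cytotoxicity, read by MTT assay, with a stated time of 72 h (on this read-out lower numbers stand for stronger inhibition and higher numbers for weaker inhibition), compound 2 gives 2500 nM, the highest of the two numbers; its nearest neighbour is compound 1, which in this assay gives 60 nM, a gap beyond the scatter. Compound 3, `COc1cc(C(=O)c2cc(OC)c(OC)c(OC)c2)cc(NC(=O)/C=C/c2cc(F)c(F)c(F)c2)c1OC`, differs from compound 2 by 3,4,5-trifluorophenyl in place of 3,4,5-trimethoxyphenyl on a double-bonded chain carbon bound to a double-bonded chain carbon. Among the measured compounds shown here, no step between measured compounds covers this change. Since compound 1, which also carries fluorine on that ring, gives 60 nM, a moderate fall beyond the scatter is expected from compound 2 to compound 3, a 3.1-fold lower number from compound 2 to compound 3 (0.49 log units; beyond the scatter). Compound 3 is expected to give about 800 nM, within 150 nM to 4000 nM.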

Compound 3, half-maximal inhibitory concentration: 5000 nM
Beside the measured number, compound 3's estimate is 6.3-fold (0.80 log units) below it; measured number above the stated range.
By their numbers in this assay, from the lowest: compound 1; then compounds 2 and 3 (each within the scatter of the next).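

In this assay the change to 3,4,5-trifluorophenyl in place of 3,4,5-trimethoxyphenyl, on a double-bonded chain carbon bound to a double-bonded chain carbon, gives a 2.0-fold higher number from compound 2 to compound 3 (0.30 log units; within the scatter) and so shows that this exchange does not separate the two compounds on this read-out. At this place on the shared core, three fluorines and three methoxy groups on the ring read alike. Nothing available explains this result. What the compounds shown leave open is whether an amine or a carboxylic acid on that ring would read differently.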